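This account rests on a few compounds, and the source may have more. Where it says the series, first, only, none or still open, it means among the compounds named here.

Measured compounds in an ADME assay for cytotoxicity, read by propidium iodide staining; a lower number here means that less compound is tolerated, a higher number that more compound is tolerated:
compound 1 `CC(C)(C)n1nc(Cc2ccc(Cl)cc2)c2ccccc2c1=O`, 72100 nM
compound 2 `CCn1nc(Cc2ccc(OC)cc2)c2ccccc2c1=O`, 89500 nM
compound 3 `Cc1ccc2c(c1)/C(=C/c1ccc(Cl)cc1)OC2=O`, "not determined" (no result reported)

In this assay compound 2 gives 89500 nM and compound 1 gives 72100 nM; the two values lie within the scatter of each other, so neither stands apart from the other, and compound 3 adds no number. Compound 4 `C=CCn1nc(Cc2ccc(OC)cc2)c2ccccc2c1=O` is not yet measured. It differs from compound 2 in one place: vinyl in place of methyl on a saturated chain carbon bound to an aromatic nitrogen. Within the data shown here, no step between two measured compounds is available to calibrate a change of this kind. Given the small size of the change, the expected step is none beyond the scatter, a 1.1-fold lower number from compound 2 to compound 4 (0.02 log units; within the scatter). Compound 4 is therefore expected to give 85000 nM, with a range from 45000 nM to 160000 nM.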

Compound 4, half-maximal cytotoxic concentration: 68600 nM
Beside the measured number, compound 4's estimate is 1.2-fold (0.09 log units) above it; the range from low to high includes it.
By their numbers in this assay, from the lowest: compounds 4, 1 and 2 (each within the scatter of the next).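

Vinyl in place of methyl on a saturated chain carbon bound to an aromatic nitrogen, the same difference as ethyl to allyl, provides the only one-place step shown in this assay and gives a 1.3-fold lower number from compound 2 to compound 4 (0.12 log units; within the scatter) in this single pair. At this position, the added carbon and double bond therefore leave the read-out within the scatter. Nothing measured here bears on a cause for this step. Open, going by these compounds, is whether a longer chain, an amine or a carboxylic acid at this position would also stay within the scatter.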